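Trimming a Butyl Chain: From Compound 1 to Compound 3

A few compounds are considered here, and "the series" means these few. Any claim that something is new, unique, unknown or untested is made for them only; others in the source may bear on it.

Measured so far:
compound 1, `CCCCOC(=O)Nc1ccc([Se]C#N)cc1`: 12.6%
compound 2, `N#C[Se]c1ccc(NC(=O)Oc2ccc(Cl)cc2)cc1`: > 25%

Of the compounds shown here, two have been tested in a physicochemical assay, with a stated time of 6 min, tested at 0.1 mg/mL; a higher number here means more inhibition at the concentration tested (going by the name of the read-out), a lower number less inhibition. Compound 1 gives 12.6% in this assay, and this is the only plain number among the results shown. Compound 2 is reported only as a limit of the assay, > 25%, not as a number. The summary the limit of > 25% in this assay, at which 1 of the 2 values shown sits, notes that one of the two values sits at this limit.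

Compound 3, `CCOC(=O)Nc1ccc([Se]C#N)cc1`, has not yet been measured in this assay. It differs from compound 1 in one place: hydrogen in place of ethyl on a saturated chain carbon, two bonds along the chain from an oxygen next to a carbonyl group. For the measured compounds named here, no step between two measured compounds that differ in a single place is available, so there is no yardstick for how this kind of shortening shifts the inhibition. A change no larger than the usual scatter, in either direction, is the reasonable expectation. For compound 3 the expected value in this assay is 12%, with a range from 4% to 22%. The step of a number 0.6 percentage points lower from compound 1 to compound 3 (within the scatter) is estimated to stay within the scatter of repeated measurements.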

Compound 3, a percentage reported as inhibition, at one concentration (the size of the read-out at that concentration, not a potency): 26.3%
Compound 3: middle estimate off by 14.3 percentage points, on the low side, outside the stated range (above it).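

Replacing ethyl with hydrogen on a saturated chain carbon, two bonds along the chain from an oxygen next to a carbonyl group, turns butoxy into ethoxy, and in this assay this change gives a number 13.7 percentage points higher from compound 1 to compound 3 (beyond the scatter). For the compounds shown here, this is the first step between two measured compounds that differ in one place, and it shows that the outer part of this chain is not a silent passenger: the read-out responds when those two carbons go, and the shorter chain gives the higher inhibition. Nothing among the results shown explains why the shorter chain behaves this way.

A single step with two chain lengths marks a direction for this pair only and does not establish a trend across chain lengths in general. On these data alone, whether the same direction would hold for a still shorter methoxy, for a longer chain such as hexyloxy, or for a chain ending in an amine or a carboxylic acid remains open.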